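The compounds below may be only part of what the source reports. "The series", "measured", "known", "first", "only" and "open" are said of these compounds alone.

Measured compounds:
compound 1 `CC1(C)Oc2ccc(C#N)cc2[C@H](Nc2ccccc2)[C@H]1O`: 1200 nM
compound 2 `CCOC(=O)CN(c1ccc(F)cc1)[C@H]1c2cc(C#N)ccc2OC(C)(C)[C@@H]1O`: > 30000 nM
compound 3 `CCOC(=O)CN(c1ccc(Cl)cc1)[C@H]1c2cc(C#N)ccc2OC(C)(C)[C@@H]1O`: > 30000 nM

Among the compounds with values here, in a functional assay (aorta) with Rattus norvegicus as the target (a lower number here means a stronger inhibitor, a higher number a weaker inhibitor), compound 1 gives 1200 nM, the only number among the three values shown. For compound 2 the value > 30000 nM is a limit of the assay, not a number. For compound 3 the value > 30000 nM is likewise a limit. Within the data shown here, the single measured step, a step that the two limits leave unreadable from compound 2 to compound 3, therefore yields nothing usable, and the limit of > 30000 nM in this assay, at which 2 of the 3 values shown sit, marks where two of the three values sit. Compound 4 `CCNC(=O)CN(c1ccccc1)[C@H]1c2cc(C#N)ccc2OC(C)(C)[C@@H]1O` differs from compound 1 by (ethylcarbamoyl)methyl in place of hydrogen on a nitrogen on an aromatic ring. Among the measured compounds shown here, no measured step covers this change alone; compounds 2 and 3, which also carry a group on that nitrogen, both reach only the limit, whereas compound 1 alone gives a number. Compound 4 is therefore expected to weaken, with a 10-fold higher number from compound 1 to compound 4 (1.00 log units; beyond the scatter) as the estimated step. Compound 4 is estimated in this assay at 12000 nM, expected to fall between 2500 nM and 30000 nM.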

Compound 4, half-maximal inhibitory concentration: > 30000 nM
Compound 4 was reported as a limit (the forecaster's own chance of this, stated with the estimate: 40%); at least 2.5-fold (0.39 log units) between middle value and limit.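

In this assay, within the data shown here, (ethylcarbamoyl)methyl in place of hydrogen on a nitrogen on an aromatic ring gives an at least 25-fold higher number from compound 1 to compound 4 (1.39 log units; beyond the scatter), the first readable step at this position. The value of compound 4, > 30000 nM, is a limit of the assay, so this step gives only the least size of the loss. Compound 4 joins the compounds at that ceiling: the limit of > 30000 nM in this assay, at which 3 of the 4 values shown sit.

The compounds shown leave open whether a plain methyl on this nitrogen would still give a number in this assay. They also leave open whether a carboxylic acid or an amine in place of the ethylcarbamoyl end would.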